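This account rests on a few compounds, and the source may have more. Where it says the series, first, only, none or still open, it means among the compounds named here.

Measured compounds in the series:
compound 1, `COc1ccc(C(=O)NNc2nc3ccccc3nc2Cc2ccccc2)cc1` — 920000 nM
compound 2, `O=C(Cn1c(=O)c(Cc2ccccc2)nc2ccccc21)NNC(=O)c1ccc(Cl)cc1` — 880000 nM

In an assay for inhibition of Amine oxidase [flavin-containing] B (Bos taurus), read by fluorescence, with a stated time of 60 min (on this read-out higher numbers stand for weaker inhibition and lower numbers for stronger inhibition), compound 1 gives 920000 nM and compound 2 gives 880000 nM; the two values lie within the scatter of each other, so neither compound can be set apart from the other. Both sit at the weak end of the measurable range.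

Compound 3, `COc1ccc(/C=N/NC(=O)Cn2c(=O)c(Cc3ccccc3)nc3ccccc32)cc1`, is not yet measured. It carries a group of 10 heavy atoms (8 carbon, 1 nitrogen, 1 oxygen; one six-membered aromatic ring of carbon only) in place of a group of 10 heavy atoms (7 carbon, 1 nitrogen, 1 oxygen, 1 chlorine; one six-membered aromatic ring of carbon only), on an amide-type nitrogen. Among the compounds with values here, no step between measured compounds covers a change of this kind, so the expectation rests only on the values of compound 1 and compound 2. A change of no more than the scatter is expected, with a 1.1-fold lower number from compound 2 to compound 3 (0.04 log units; within the scatter) as the expected step. For compound 3 an estimate of 800000 nM is made, with a range from 250000 nM to 2500000 nM.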

Compound 3, half-maximal inhibitory concentration: 82000 nM
The estimate for compound 3 lay 9.8-fold (0.99 log units) above the measured number; the measured number lies below the stated range.
By their numbers in this assay, from the lowest: compound 3; then compounds 2 and 1 (each within the scatter of the next).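

In this assay, within the data shown here, this position on the amide-type nitrogen proves sensitive: the change gives an 11-fold lower number from compound 2 to compound 3 (1.03 log units; beyond the scatter), the first step beyond the scatter. The entering group has the same heavy-atom count as ((4-chlorophenyl)carbonyl)amino, but it has no chlorine and counts 0 hydrogen-bond donors and 2 acceptors against 1 and 1, so several features change in this one step. Nothing measured here accounts for the step.

The compounds shown leave open which of these features carries the step. A 4-chlorophenyl ring or a dimethylamino group on the group of compound 3 would bear on this.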